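The compounds below may be only part of what the source reports. "The series", "measured", "known", "first", "only" and "open" are said of these compounds alone.

Measured so far:
- compound 1, `CCc1cccc(Nc2cc(NC(=O)Nc3cc(OC)cc(OC)c3)ncn2)c1`: 82.1%
- compound 2, `Cc1ccc(Nc2cc(NC(=O)Nc3c(Cl)cccc3Cl)ncn2)cc1C`: 92.1%

Both readings come from a functional assay on PC-9 cells (Homo sapiens) for inhibition, read by MTT assay, with a stated time of 48 h, tested at 10 uM; a lower number here means less inhibition, a higher number more inhibition at the concentration tested (going by the name of the read-out). Compound 1 gives the smaller of the two numbers in this assay, but the gap to compound 2 is within the usual scatter, so the two compounds cannot be told apart on these data; both sit at a high level of inhibition at the concentration tested.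

Compound 3, `COc1cc(NC(=O)Nc2cc(Nc3ccc(C(C)(C)C)cc3)ncn2)cc(OC)c1`, has not been measured. It differs from compound 1 in one place: 4-(tert-butyl)phenyl in place of 3-ethylphenyl on a nitrogen on an aromatic ring. For the measured compounds named here, no step between two measured compounds covers a change of this kind, so there is no measured guide to its size. Given that compound 1 gives 82.1% and compound 2 gives 92.1% in this assay, a change of the aryl group on the same nitrogen has so far left the read-out at a high level, and the expectation is a step from compound 1 to compound 3 of a number 4.1 percentage points lower from compound 1 to compound 3 (within the scatter), that is, none beyond the scatter in either direction.

Compound 3 is therefore estimated at 78% in this assay, with a range from 55% to 93%.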

Compound 3, a percentage reported as inhibition, at one concentration (the size of the read-out at that concentration, not a potency): 74.1%
Compound 3: the middle estimate sits 3.9 percentage points above what was measured; the measured number falls inside the stated range.
By their numbers in this assay, from the lowest: compounds 3, 1 and 2 (each within the scatter of the next, the first and the last beyond it).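

In this assay, for the compounds shown here, the step is a number 8 percentage points lower from compound 1 to compound 3 (within the scatter) for 4-(tert-butyl)phenyl in place of 3-ethylphenyl on a nitrogen on an aromatic ring, the first one-place comparison at this nitrogen. On this single pair, the two carbon-only aryl groups cannot be told apart at this nitrogen, with the dimethoxyphenyl urea part of the molecule held constant, and the pair gives no ranking of the two groups. No measurement on hand accounts for the size of this step.

As far as these compounds go, both aryl groups compared here carry only alkyl substituents, so it remains open whether an amine, a carboxylic acid or a morpholine on the aryl group at this nitrogen would move the reading beyond the scatter. From the compounds shown here alone, a percentage at one concentration is not a potency, and whether compound 1 and compound 3 differ in potency also remains open.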